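The source may hold more compounds than are shown below. What is called first, only, known or untested is meant among the compounds shown, and "the series" means these compounds.

Measured in a functional assay on SK-BR-3 cells (Homo sapiens) for antiproliferative activity, read by MTT assay, with a stated time of 72 h; on this read-out lower numbers stand for stronger inhibition and higher numbers for weaker inhibition:

Compound 1, `C/C=C1/[C@H](O[C@@H]2O[C@H](CO)[C@@H](O)[C@H](O)[C@H]2O)OC=C(C(=O)OC)[C@H]1CC(=O)OCc1ccc2c(c1)OCCO2`: > 15000 nM
Compound 2, `C/C=C1/[C@H](O[C@@H]2O[C@H](COC(C)=O)[C@@H](OC(C)=O)[C@H](OC(C)=O)[C@H]2OC(C)=O)OC=C(C(=O)O)[C@H]1CC(=O)O`: > 20000 nM
Compound 3, `C/C=C1/[C@H](O[C@@H]2O[C@H](COC(C)=O)[C@@H](OC(C)=O)[C@H](OC(C)=O)[C@H]2OC(C)=O)OC=C(C(=O)OC)[C@H]1CC(=O)OCC`: > 15000 nM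

Each of these values is a limit of the assay and not a number. Compound 1 stands at the limit of > 15000 nM in this assay, at which 2 of the 3 values shown sit. Compound 3 sits at that same limit. Compound 2 stands at the limit of > 20000 nM in this assay, at which 1 of the 3 values shown sits. Within the data shown here, since none of the three carries a measured number, no step between measured compounds can be counted, and compound 1 cannot be placed above or below its two companions: all three rest at the edge of what this assay reports, and nothing distinguishes them.

Compound 4, `C/C=C1/[C@H](O[C@@H]2O[C@H](CO)[C@@H](O)[C@H](O)[C@H]2O)OC=C(C(=O)OC)[C@H]1CC(=O)OCCC(C)C`, has not yet been measured. It differs from compound 1 in one place: isobutyl in place of 2,3-dihydro-1,4-benzodioxin-6-yl on a saturated chain carbon bound to an oxygen next to a carbonyl group. The ester on the side chain of the shared core thus carries isobutyl where compound 1 carries 2,3-dihydro-1,4-benzodioxin-6-yl.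

Among the measured compounds shown here, with compound 1 at a limit and no measured step in the set, compound 4 is expected to remain at or near the same limit, and the step that the limit leaves unreadable from compound 1 to compound 4 is expected to be none beyond the scatter. The estimate for compound 4 is therefore 20000 nM, with a range from 7000 nM to 60000 nM.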

Compound 4, half-maximal inhibitory concentration: 9020 nM
Estimate against measurement, compound 4: 2.2-fold (0.35 log units) above, within the range that was stated.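

In this assay compound 4 gives 9020 nM, the only value among the four compounds shown that is a number, so this place on the side-chain ester tolerates a change that yields a readable result. Compound 1, by contrast, rests at a limit of the assay and not at a number: the limit of > 15000 nM in this assay, at which 2 of the 4 values shown sit. Isobutyl in place of 2,3-dihydro-1,4-benzodioxin-6-yl, on a saturated chain carbon bound to an oxygen next to a carbonyl group, gives an at least 1.6-fold lower number from compound 1 to compound 4 (0.22 log units; that floor lies within the scatter), so the change may be larger than that floor, but the data do not establish a step beyond the scatter.

The compounds shown leave open whether the readable value of compound 4 depends on the branched isobutyl itself or would also appear with a straight chain such as n-hexyl, a longer chain such as n-octyl, or a plain benzyl group in the same place. They also cannot say how far the number would move with an amine at the end of that chain, and every other step in the set cannot be read.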